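Swapping a cyanophenyl for an aminopropyl on the amine

The source may hold more compounds than are shown below. What is called first, only, known or untested is meant among the compounds shown, and "the series" means these compounds.

Compound 1 `CC(C)Nc1sc(C(=O)c2ccc(C#N)cc2)c(N)c1C#N`: > 5000 nM
Compound 2 `N#Cc1ccccc1Nc1sc(C(=O)c2ccc(Br)s2)c(N)c1C#N`: > 5000 nM

In an assay for inhibition of Maternal embryonic leucine zipper kinase (Homo sapiens), read by ADP-Glo, with a stated time of 0.5 h (a higher number here means a weaker inhibitor, a lower number a stronger inhibitor), compound 1 gives > 5000 nM, which is a limit of the assay and not a number. Compound 2 gives > 5000 nM, likewise a limit. Compound 2 therefore stands where every value shown stands: the limit of > 5000 nM in this assay, at which 2 of the 2 values shown sit. Compound 3 `N#Cc1c(NCCCN)sc(C(=O)c2ccc(Br)s2)c1N` differs from compound 2 in one place: 3-aminopropyl in place of 2-cyanophenyl on a nitrogen on an aromatic ring. Going by the values given here, no measured pair of compounds shows what this change does, so no step size is known from the data. Compound 3 is expected to remain weak, with an expected step of an at least 1.2-fold lower number from compound 2 to compound 3 (0.09 log units; that floor lies within the scatter). For compound 3 the estimated value is 4000 nM, in a range from 800 nM to 20000 nM.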

Compound 3, half-maximal inhibitory concentration: 141 nM
The estimate for compound 3 lay 28-fold (1.45 log units) above the measured number; the whole stated range lies above it.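

In this assay, the group on this nitrogen clearly matters: 3-aminopropyl in place of 2-cyanophenyl gives an at least 35-fold lower number from compound 2 to compound 3 (1.54 log units; beyond the scatter). Going by these compounds alone, compound 3 is the first compound here to give a measured number rather than a limit. The step is only a floor because the value of compound 2 is a limit: the limit of > 5000 nM in this assay, at which 2 of the 3 values shown sit.

The compounds shown leave open whether the amine or the chain itself accounts for this step. A plain propyl chain without the amine, or a longer chain carrying an amine, would separate the two.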